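Sulfur for Selenium in the Bis-Amide Series

The compounds below may be only part of what the source reports. "The series", "measured", "known", "first", "only" and "open" are said of these compounds alone.

Compound 1 (`C[Se]/C(=N\C(=O)c1cc2ccccc2s1)NC(=O)c1cc2ccccc2s1`) is one of three measured compounds in a functional assay on HepG2 cells (Homo sapiens) for cytotoxicity, read by MTT assay, with a stated time of 72 h (a lower number here means a stronger inhibitor of growth, a higher number a weaker inhibitor of growth), where compound 1 gives 41000 nM. Compound 3 (`C[Se]/C(=N\C(=O)c1ccco1)NC(=O)c1ccco1`) gives 8660 nM, so compound 1 carries the higher of the two numbers reported, and the gap between them lies beyond the usual scatter. Compound 2 (`CS/C(=N\C(=O)c1ccno1)NC(=O)c1ccno1`) gives only a limit, > 100000 nM, in line with the limit of > 100000 nM in this assay, at which 1 of the 3 values shown sits. Compound 4 (`CS/C(=N\C(=O)c1cc2ccccc2s1)NC(=O)c1cc2ccccc2s1`) differs from compound 1 by a group of 2 heavy atoms (1 carbon, 1 sulfur; no ring) in place of a group of 2 heavy atoms (1 carbon, 1 selenium; no ring), on a carbon with a double bond to nitrogen. Among the measured compounds shown here, no measured pair isolates this exchange, and the one sulfur-bearing compound sits at the limit, so compound 4 is expected to be weaker than compound 1 by a 1.8-fold higher number from compound 1 to compound 4 (0.26 log units; within the scatter) in this assay. The estimate for compound 4 is therefore 75000 nM, between 25000 nM and 200000 nM.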

Compound 4, concentration for total growth inhibition: 53000 nM
Compound 4: middle estimate off by 1.4-fold (0.15 log units), on the high side; low and high end bracket the measured number.
By their numbers in this assay, from the lowest: compound 3; then compounds 1 and 4 (each within the scatter of the next). At a limit, above all of these: compound 2.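

The exchange of the selenium-bearing group for methylsulfanyl, on a carbon with a double bond to nitrogen, is now isolated by a single pair of compounds in this assay: the step is a 1.3-fold higher number from compound 1 to compound 4 (0.11 log units; within the scatter). At this position, on this core, the assay does not tell the two groups apart. Nothing shown accounts for this result. On these data alone, whether the exchange reads the same on the core of compound 3 remains open. So does the effect of an amine or a longer chain on that carbon.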